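The source may report more compounds than this note shows. Statements on the series, on what has been measured and on what is new or still open speak of the compounds shown alone.

Measured compounds in an assay on HeLa cells for displacement of a labelled ligand from thyroid hormone receptor alpha (Homo sapiens); a lower number here means a stronger inhibitor, a higher number a weaker inhibitor:
compound 1 `Cc1cc(OCC(=O)O)cc2cc(C)n(Cc3ccc(O)c(C(C)C)c3)c12` gives 2.05 nM
compound 2 `Cc1cc2cc(OCC(=O)O)cc(Cl)c2n1Cc1ccc(O)c(C(C)C)c1` gives 0.38 nM
compound 3 `Cc1cn(Cc2ccc(O)c(C(C)C)c2)c2c(C)cc(OCC(=O)O)cc12` gives 2.77 nM

Compound 1 and compound 2 share one core; the move between them is chloro in place of methyl on an aromatic carbon. That single change gave a 5.4-fold lower number from compound 1 to compound 2 (0.73 log units; beyond the scatter).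

Compound 3 carries a different core built from the same atoms joined differently; the difference between the two cores is not broken down here. Its value in this assay and that of compound 1 are within the usual scatter of each other, so nothing can be said about order between them. Compound 2 stands apart from compound 3 beyond the scatter.

Compound 4 `Cc1cn(Cc2ccc(O)c(C(C)C)c2)c2c(Cl)cc(OCC(=O)O)cc12` is not yet measured. Relative to compound 3 it shows (chloro in place of methyl on an aromatic carbon), the same change as that from compound 1 to compound 2, at a place described in the same words. In this assay the step is expected to be a 4.6-fold lower number from compound 3 to compound 4 (0.66 log units; beyond the scatter), resting on the step seen from compound 1 to compound 2, a 5.4-fold lower number from compound 1 to compound 2 (0.73 log units; beyond the scatter), with some allowance for the core being different. Compound 4 is therefore estimated at 0.6 nM, expected to fall between 0.25 nM and 1.5 nM.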

Compound 4, inhibition constant: 0.51 nM
Estimate against measurement, compound 4: 1.2-fold (0.07 log units) above, and the stated range covers the measured number.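

In this assay, chloro in place of methyl on an aromatic carbon gave a 5.4-fold lower number from compound 3 to compound 4 (0.73 log units; beyond the scatter), and the step carried from the core of compound 1 to the core of compound 3 with no measurable difference in size: the same change on two cores in this assay, a 5.4-fold lower number (0.73 log units; beyond the scatter) from compound 1 to compound 2 and a 5.4-fold lower number (0.73 log units; beyond the scatter) from compound 3 to compound 4, 1.0-fold (0.00 log units) apart, within the scatter of two such steps

For these two cores, built from the same atoms joined differently, the size of the step read on one core therefore served for the other. For the compounds shown here, this rests on only two pairs in a single assay, and it does not show that the step would hold on any further core, or with other parts of the compounds altered, nor does it say why the change has this size.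

Open, going by these compounds, is whether other groups at this place, such as fluoro, bromo or trifluoromethyl, would match or pass chloro. Also open, on these data alone, is whether the step survives when the carboxymethoxy group gives way to a longer chain ending in a carboxylic acid or to an amide.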